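The compounds below may be only part of what the source reports. "The series", "measured", "known", "first", "only" and "open" are said of these compounds alone.

Working notes on three measured compounds sharing one core, tested in a functional assay on MDA-MB-231 cells (Homo sapiens) for antiproliferative activity, read by MTT assay, with a stated time of 72 h; a lower number here means a stronger inhibitor, a higher number a weaker inhibitor. Compound 1 `O=C(CCc1cccc2c1B(O)OC2)Nc1ccc(Cl)cc1` gives 3600 nM, compound 2 `Cc1ccc(NC(=O)CCc2cccc3c2B(O)OC3)cc1` gives 1100 nM and compound 3 `CC(C)(C)c1ccc(NC(=O)CCc2cccc3c2B(O)OC3)cc1` gives 33000 nM. Compound 3 therefore has the highest number of the three and is the weakest inhibitor so far.

The next step leads to compound 4 `COc1ccc(NC(=O)CCc2cccc3c2B(O)OC3)cc1`: methoxy in place of tert-butyl on an aromatic carbon, para to a large group. For the measured compounds named here, no methoxy compound has yet been measured, so the evidence is indirect. Two measured steps introduce tert-butyl at this place, and both raise the number: a 9.2-fold higher number from compound 1 to compound 3 (0.96 log units; beyond the scatter), which is modest, and a 30-fold higher number from compound 2 to compound 3 (1.48 log units; beyond the scatter), which is large. The step of a 3.3-fold lower number from compound 1 to compound 2 (0.51 log units; beyond the scatter) shows that the two non-tert-butyl groups also differ from each other, which limits the precision of any estimate.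

Removing tert-butyl is expected to reverse much of that rise, with a size between those two steps. The expected change is a 17-fold lower number from compound 3 to compound 4 (1.22 log units; beyond the scatter). Compound 4 is estimated at 2000 nM, with an expected range from 700 nM to 6000 nM.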

Compound 4, half-maximal inhibitory concentration: 850 nM
For compound 4 the middle estimate is 2.4-fold (0.37 log units) above the measured one, within the range that was stated.
By their numbers in this assay, from the lowest: compounds 4 and 2 (each within the scatter of the next); then compound 1; then compound 3.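

In this assay, methoxy in place of tert-butyl at this position gives a 39-fold lower number from compound 3 to compound 4 (1.59 log units; beyond the scatter), so all three other groups shown now stand clearly below tert-butyl, and the high number of compound 3 no longer rests on comparisons with methyl and chloro alone. Methoxy and methyl cannot be separated here, at a 1.3-fold lower number from compound 2 to compound 4 (0.11 log units; within the scatter), while the change from chloro gives a 4.2-fold lower number from compound 1 to compound 4 (0.63 log units; beyond the scatter), which places chloro apart from both of these groups. No measurement is available to explain these differences.

On these data alone, it remains open where the number begins to rise between methyl and tert-butyl, a question that an ethyl or isopropyl group at this place would address, and whether an ethoxy group would match methoxy. The compounds shown also leave open how an amine or a carboxylic acid at this place would behave.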